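The source may hold more compounds than are shown below. What is called first, only, known or untested is meant among the compounds shown, and "the series" means these compounds.

Compound 1 `CC(C)COc1ccc2c(Cl)ccnc2c1` — 3100 nM
Compound 2 `CCCCCCCCOc1ccc2c(Cl)ccnc2c1` — 4500 nM

Both compounds were tested in a functional assay on DLD-1 cells (Homo sapiens) for cytotoxicity, read by MTT assay, with a stated time of 48 h; on this read-out lower numbers stand for stronger inhibition and higher numbers for weaker inhibition. Compound 1 `CC(C)COc1ccc2c(Cl)ccnc2c1` gives 3100 nM. Compound 2 `CCCCCCCCOc1ccc2c(Cl)ccnc2c1` gives 4500 nM. Compound 2 stands at the upper end of these two numbers, but the gap to compound 1 lies within the usual scatter of repeated measurements, so the two count as alike on this read-out. Going by the values given here, no step between these two compounds is worked out here, and their two values alone say only that the shared core tolerates either side chain with a similar outcome.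

Compound 3 `CCCCCCOc1ccc2c(Cl)ccnc2c1` has not yet been measured in this assay. It differs from compound 2 in one place: hydrogen in place of ethyl on a saturated chain carbon, six bonds along the chain from an oxygen on an aromatic ring. The chain is shortened by that amount; the rest of the molecule is unchanged.

Among the compounds with values here, with only two measured compounds, both giving closely similar numbers despite very different chain lengths, no step beyond the scatter is expected from compound 2 to compound 3. The estimate for compound 3 in this assay is 3800 nM, with a range from 1500 nM to 9500 nM, meaning an expected step of a 1.2-fold lower number from compound 2 to compound 3 (0.07 log units; within the scatter).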

Compound 3, half-maximal inhibitory concentration: 2660 nM
Estimate against measurement, compound 3: 1.4-fold (0.15 log units) above; the range from low to high includes it.
By their numbers in this assay, from the lowest: compounds 3, 1 and 2 (each within the scatter of the next).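

With hydrogen in place of ethyl on a saturated chain carbon, six bonds along the chain from an oxygen on an aromatic ring, this assay gives a 1.7-fold lower number from compound 2 to compound 3 (0.23 log units; within the scatter) and this step lies within the usual scatter, so removing this end of the chain makes no readable difference here. The second step, with pentyl in place of isopropyl on a saturated chain carbon bound to an oxygen on an aromatic ring, is a 1.2-fold lower number from compound 1 to compound 3 (0.07 log units; within the scatter) and also lies within the scatter, so among these three compounds a branched chain and an unbranched one of different lengths come out alike. Nothing shown here accounts for how closely these numbers agree.

Going by these compounds, all three side chains are plain saturated carbon chains, so what a chain ending in an amine or a carboxylic acid would give in this assay remains open. Also open, on these data alone, is whether the numbers stay alike with a group as small as methyl on that oxygen, or with a ring such as phenyl at the end of the chain.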